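Swapping fluorine for chlorine on the benzyl ring

The source may hold more compounds than are shown below. What is called first, only, known or untested is meant among the compounds shown, and "the series" means these compounds.

Compound 3 `Cc1cc(C)c(Oc2cc(Nc3ccc(C#N)cc3)ncc2C(=O)NCc2cn(Cc3ccc(F)cc3)nn2)c(C)c1` is one of three compounds tested for how much of them cells can tolerate. In an ADME assay on MT4 cells (Homo sapiens) for cytotoxicity, read by MTT assay, with a stated time of 5 days (a higher number here means that more compound is tolerated, a lower number that less compound is tolerated), compound 3 is reported only as a limit, >= 153000 nM. Compound 1 `Cc1cccc(Cn2cc(CNC(=O)c3cnc(Nc4ccc(C#N)cc4)cc3Oc3c(C)cc(C)cc3C)nn2)c1` gives 114000 nM in this assay, and compound 2 `COC(=O)Cn1cc(CNC(=O)c2cnc(Nc3ccc(C#N)cc3)cc2Oc2c(C)cc(C)cc2C)nn1` gives 13800 nM. Both an at least 1.3-fold higher number from compound 1 to compound 3 (0.12 log units; that floor lies within the scatter) and an at least 11-fold higher number from compound 2 to compound 3 (1.04 log units; beyond the scatter) run up to the limit (the limit of >= 153000 nM in this assay, at which 1 of the 3 values shown sits). Compound 4 `Cc1cc(C)c(Oc2cc(Nc3ccc(C#N)cc3)ncc2C(=O)NCc2cn(Cc3ccc(Cl)cc3)nn2)c(C)c1` differs from compound 3 by chloro in place of fluoro on an aromatic carbon. For the measured compounds named here, no measured step swaps one halogen for another on that ring; the closest change, an at least 1.3-fold higher number from compound 1 to compound 3 (0.12 log units; that floor lies within the scatter), stayed within the scatter, so no step beyond the scatter is expected in this assay. Compound 4 is therefore expected to give 140000 nM, between 60000 nM and 300000 nM, a step of an at least 1.0-fold lower number from compound 3 to compound 4 (0.03 log units; that floor lies within the scatter), quite possibly reported again only as a limit.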

Compound 4, half-maximal cytotoxic concentration: >= 120000 nM
Compound 4: a limit, no number; the forecaster's own chance of this, stated with the estimate: 55%; the middle value is on the limit's open side.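

Compound 4, like compound 3, is reported only as a limit, so the step from fluoro to chloro on this ring cannot be read: the limit of >= 120000 nM in this assay, at which 1 of the 4 values shown sits.

What is new is that a second halogen at this place gives a result in this assay much like the first: against methoxycarbonyl, 4-chlorophenyl gives an at least 8.6-fold higher number from compound 2 to compound 4 (0.93 log units; beyond the scatter). Against 3-methylphenyl it gives an at least 1.0-fold higher number from compound 1 to compound 4 (0.02 log units; that floor lies within the scatter), and that floor separates the two no more than the scatter does.

Where compound 3 and compound 4 truly lie remains open, so the two halogens cannot be ranked. Also open, going by these compounds, is how an amine or a carboxylic acid on this benzyl ring would fare.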